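Anilino for 4-acetylpiperazin-1-yl on the aromatic carbon

The source may hold more compounds than are shown below. What is called first, only, known or untested is meant among the compounds shown, and "the series" means these compounds.

Notes on the series. Compound 1 `CN(c1cccc2c1CN(c1nc(Nc3ccc(C(F)(F)F)cc3)ncc1C(F)(F)F)C2)S(C)(=O)=O` carries a trifluoromethyl on the aromatic carbon of the anilide ring. In a functional assay on A549 cells (Homo sapiens) for antiproliferative activity, read by spectrophotometry, with a stated time of 2 days (on this read-out higher numbers stand for weaker inhibition of growth and lower numbers for stronger inhibition of growth), compound 1 gives only a limit, > 30000 nM, not a number. Compound 2 `CC(=O)N1CCN(c2ccc(Nc3ncc(C(F)(F)F)c(N4Cc5cccc(N(C)S(C)(=O)=O)c5C4)n3)cc2)CC1` places 4-acetylpiperazin-1-yl at that carbon, and in this assay compound 2 gives 1300 nM. For the measured compounds named here, the step of an at least 23-fold lower number from compound 1 to compound 2 (1.36 log units; beyond the scatter) is the only measured step in the set, and it starts from a limit (the limit of > 30000 nM in this assay, at which 1 of the 2 values shown sits). Compound 2 thus stands as the sole compound with a number shown; the other value is a limit.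

Compound 3 `CN(c1cccc2c1CN(c1nc(Nc3ccc(Nc4ccccc4)cc3)ncc1C(F)(F)F)C2)S(C)(=O)=O` differs from compound 2 in one place: anilino in place of 4-acetylpiperazin-1-yl on an aromatic carbon. Going by the values given here, no measured step swaps 4-acetylpiperazin-1-yl for anilino, so the one large step from compound 1 to compound 2 tells only that this carbon tolerates a sizeable group, not how anilino compares with 4-acetylpiperazin-1-yl. Among the compounds with values here, with no direct precedent, the expected step of a 1.2-fold higher number from compound 2 to compound 3 (0.06 log units; within the scatter) is small, within the scatter, in no set direction. For compound 3 the estimate in this assay is 1500 nM, with a range of 400 nM to 6000 nM.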

Compound 3, concentration for 50% growth inhibition: 6200 nM
Compound 3: middle estimate off by 4.1-fold (0.62 log units), on the low side, outside the stated range (above it).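

In this assay, for the compounds shown here, anilino in place of 4-acetylpiperazin-1-yl gives a 4.8-fold higher number from compound 2 to compound 3 (0.68 log units; beyond the scatter), so two sizeable groups on this aromatic carbon are not interchangeable, a point the single earlier step could not show. Anilino still stands clear of trifluoromethyl, with an at least 4.8-fold lower number from compound 1 to compound 3 (0.68 log units; beyond the scatter), so both larger groups give a measurable number where trifluoromethyl does not, and the order at this carbon runs from 4-acetylpiperazin-1-yl through anilino to trifluoromethyl. The last step is a bound and not a measured size, since compound 1 gives only a limit: the limit of > 30000 nM in this assay, at which 1 of the 3 values shown sits.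

The two groups differ in several ways at once, in the non-aromatic ring, the acetyl carbonyl and the hydrogen-bond donor of anilino, and the compounds shown do not say which of these goes with the step; a piperazine without the acetyl, a morpholine or a phenoxy group on this carbon would help to separate them. From the compounds shown here alone, whether the same order holds with anything other than the trifluoromethyl and the methanesulfonamide of the shared core, for instance a nitrile in place of that trifluoromethyl, also stays open.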